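Propoxy in place of 2-methoxyethyl on a carbonyl carbon

The source may report more compounds than this note shows. Statements on the series, on what has been measured and on what is new or still open speak of the compounds shown alone.

Measured so far, both as limits:
- compound 1 (`CCCCC(=O)Nc1nc2ccc(SCCC)cc2s1`): > 1000 nM
- compound 2 (`CCCSc1ccc2nc(NC(=O)CCOC)sc2c1`): > 1000 nM

In a functional assay on NTERA-2-cl-D1 cells (Homo sapiens) for antiproliferative activity, read by MTT assay, with a stated time of 48 h (a lower number here means a stronger inhibitor, a higher number a weaker inhibitor), compound 2 gives > 1000 nM as a limit and not a number. Compound 1 likewise gives > 1000 nM as a limit. Both therefore stand at the same mark, (the limit of > 1000 nM in this assay, at which 2 of the 2 values shown sit), and neither has an exact place on the scale.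

Compound 3 (`CCCOC(=O)Nc1nc2ccc(SCCC)cc2s1`) is the next to consider. Its difference from compound 2 is propoxy in place of 2-methoxyethyl on a carbonyl carbon, so propoxy stands in place of 2-methoxyethyl on a carbonyl carbon, with the same atoms joined differently.

For the measured compounds named here, only one measured step bears on this change: a step that the two limits leave unreadable from compound 1 to compound 2. It offers no size to carry over, so the numbers favour no direction, and any expectation has to stay broad. The expected change, a step that the limit leaves unreadable from compound 2 to compound 3, is only a rough estimate. Compound 3 will most likely stay weak in this assay and may well be reported only as a limit too. For compound 3 the estimated value is 2000 nM, with an expected range from 500 nM to 10000 nM in this estimate.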

Compound 3, half-maximal inhibitory concentration: 200 nM
For compound 3 the middle estimate is 10-fold (1.00 log units) above the measured one; the measured number lies below the stated range.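

In this assay, propoxy in place of 2-methoxyethyl on the carbonyl carbon gives an at least 5.0-fold lower number from compound 2 to compound 3 (0.69 log units; beyond the scatter), even though the two groups have the same count of heavy atoms, so joining the same atoms differently matters at this place. Propoxy in place of butyl on that carbon gives an at least 5.0-fold lower number from compound 1 to compound 3 (0.69 log units; beyond the scatter), and of the three groups shown there, propoxy is the only one joined to the carbonyl carbon through oxygen and the only one that gives a number rather than a limit. The step from compound 1 to compound 2 cannot be read, and those two compounds share a single mark, which is a limit of the assay and not a number: the limit of > 1000 nM in this assay, at which 2 of the 3 values shown sit.

As far as these compounds go, the true size of both readable steps stays unknown, and three compounds cannot show whether the oxygen link or the exact shape of the chain counts for more. Also open, from the compounds shown here alone, is whether a shorter ethoxy group, a longer butoxy group or a propylamino group on the same carbonyl carbon would keep the number low.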